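Fluoro in place of hydrogen: compound 2 to compound 3

A few compounds are considered here, and "the series" means these few. Any claim that something is new, unique, unknown or untested is made for them only; others in the source may bear on it.

Of the compounds shown here, two on the shared core have been measured in an assay on isolated protein for inhibition of Ca2+/calmodulin-dependent protein kinase II (CaM kinase II) (Rattus norvegicus), tested at 30 uM; on this read-out higher numbers stand for more inhibition at the one concentration tested (going by the name of the read-out) and lower numbers for less inhibition. Compound 1 `Fc1ccc(Cn2cnc3c(Cl)ncnc32)cc1` gives 0% in this assay. Compound 2 `Cn1cnc2c(-c3ccccc3)ncnc21` gives 8% in this assay. Among the measured compounds shown here, compound 2 holds one of only two numbers at hand, and the other, from compound 1, lies within the usual scatter of it, so the two cannot be ranked against each other. For the measured compounds named here, no pair among the measured compounds differs in a single place, so no measured step exists to draw on.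

Compound 3 `Cn1cnc2c(-c3ccc(F)cc3)ncnc21` has not been measured. It differs from compound 2 by fluoro in place of hydrogen on an aromatic carbon. Going by the values given here, the series offers no measured step of this kind, so nothing points to a shift beyond the scatter; the change adds one heavy atom, and the starting point is modest because compound 2 gives 8%. The expected step is a number 2 percentage points higher from compound 2 to compound 3 (within the scatter), within the scatter. Compound 3 is estimated at 10%, with a range of 0% to 25%.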

Compound 3, a percentage reported as inhibition, at one concentration (the size of the read-out at that concentration, not a potency): 12%
Beside the measured number, compound 3's estimate is 2 percentage points below it, within the range that was stated.
By their numbers in this assay, from the lowest: compounds 1, 2 and 3 (each within the scatter of the next, the first and the last beyond it).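

In this assay the series now has its first step between compounds that differ in one place: the step of a number 4 percentage points higher from compound 2 to compound 3 (within the scatter) comes with fluoro in place of hydrogen on an aromatic carbon, para to a large group. At this position on the six-membered aromatic ring of carbon only, then, one added fluorine atom gives a reading that cannot be told apart from that of compound 2, something the two earlier compounds, which differ in more than one place, could not show. Nothing at hand speaks to why the reading behaves this way at this position.

The compounds shown leave open whether a different group at this same place, such as an amine, a methoxy group or a carboxylic acid, would give a step beyond the scatter. They also leave open whether fluoro on another carbon of this ring, or a longer chain in place of the methyl group on the shared core, would read any differently from compound 2 at the one concentration tested.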